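Propanoyl to vinylcarbonyl on the shared core

The source may hold more compounds than are shown below. What is called first, only, known or untested is meant among the compounds shown, and "the series" means these compounds.

In a functional assay on Caco-2 cells (Homo sapiens) for cytotoxicity, read by MTT assay, with a stated time of 4 h (on this read-out higher numbers stand for weaker inhibition and lower numbers for stronger inhibition), compound 1 (`COC(=O)C1=CO[C@@H](O[C@@H]2O[C@H](COC(c3ccccc3)(c3ccccc3)c3ccccc3)[C@@H](O)[C@H](O)[C@H]2O)[C@@H]2[C@@H](C)[C@@H](O)C[C@H]12`) gives 0.56 ug/mL as its reading. Compound 2 (`CCC(=O)OC[C@H]1O[C@@H](O[C@@H]2OC=C(C(=O)OC)[C@H]3C[C@H](OC(C)=O)[C@H](C)[C@@H]23)[C@H](OC(C)=O)[C@@H](OC(C)=O)[C@@H]1OC(C)=O`) gives 2.85 ug/mL and holds the higher of the two numeric values, beyond the scatter from compound 1. Compound 3 (`CCCCCCCCCCCCCC(=O)OC[C@H]1O[C@@H](O[C@@H]2OC=C(C(=O)OC)[C@H]3C[C@H](OC(C)=O)[C@H](C)[C@@H]23)[C@H](OC(C)=O)[C@@H](OC(C)=O)[C@@H]1OC(C)=O`) gives "not active" (no number reported) as its entry, so it cannot be placed on the numeric scale. Compound 4 (`C=CC(=O)OC[C@H]1O[C@@H](O[C@@H]2OC=C(C(=O)OC)[C@H]3C[C@H](OC(C)=O)[C@H](C)[C@@H]23)[C@H](OC(C)=O)[C@@H](OC(C)=O)[C@@H]1OC(C)=O`) has not yet been measured.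

The change from compound 2 to compound 4 reads vinyl in place of ethyl on a carbonyl carbon and amounts to vinyl in place of ethyl on a carbonyl carbon. Among the compounds with values here, no pair of measured compounds isolates this change, so the series offers no direct precedent for it. A step within the scatter is expected in this assay with no firm direction. The estimated move is a 1.2-fold lower number from compound 2 to compound 4 (0.07 log units; within the scatter) and it is expected to stay within the scatter. The estimate for compound 4 is 2.4 ug/mL with an expected range from 0.8 ug/mL to 7.5 ug/mL as its bounds. An entry without a number, like that of compound 3, remains possible.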

Compound 4, half-maximal inhibitory concentration: "not active" (no number reported)
Compound 4: no number reported, and the estimate cannot be compared.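

In this assay, within the data shown here, compound 4 carries no number, and no step from compound 2 to compound 4 can be read. No available evidence bears on this result. The compounds shown leave open whether vinyl in place of ethyl on a carbonyl carbon changes the reading.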